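From Methoxy to Ethoxy: Expected Cytotoxicity of Compound 4

The source may report more compounds than this note shows. Statements on the series, on what has been measured and on what is new or still open speak of the compounds shown alone.

In a functional assay on L5178Y cells (Mus musculus) for cytotoxicity, read by MTT assay (on this read-out lower numbers stand for an effect already at smaller amounts and higher numbers for an effect only at larger amounts of compound), compound 1 `CC1=C(CC/C(C)=C/CC/C(C)=C/CCC2=CC(=O)OC2O)C(C)(C)CCC1=O` gives only > 10 ug/mL, which is a limit of the assay rather than a number. Compound 2 `CC1=C(CC/C(C)=C/CC/C(C)=C/CCC2=CC(=O)OC2O)C(C)(C)CCC1` gives 3.3 ug/mL, and compound 3 `COC1OC(=O)C=C1CC/C=C(\C)CC/C=C(\C)CCC1=C(C)CCCC1(C)C` gives 0.7 ug/mL, the lowest of the two numbers measured. Going by the values given here, the only step that bears on the next change is a 4.7-fold lower number from compound 2 to compound 3 (0.67 log units; beyond the scatter), brought about by a methyl in place of hydrogen on an oxygen on a saturated carbon. Compound 4 `CCOC1OC(=O)C=C1CC/C=C(\C)CC/C=C(\C)CCC1=C(C)CCCC1(C)C` carries the change (methyl in place of hydrogen on a saturated chain carbon bound to an oxygen on a saturated carbon), that is, methoxy to ethoxy. Since adding one carbon gave a modest gain in that step, a second small carbon is expected to leave the number near compound 3, with a step of a 1.4-fold lower number from compound 3 to compound 4 (0.15 log units; within the scatter) within or just beyond the scatter. Compound 4 is therefore expected to give 0.5 ug/mL, somewhere between 0.2 ug/mL and 1.5 ug/mL.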

Compound 4, concentration for half-maximal effect: > 100 ug/mL
Compound 4 ended at the assay's limit; the forecaster's own chance of this, stated with the estimate: 2%; middle value at least 200-fold (2.30 log units) from the limit.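

In this assay, going from methoxy to ethoxy gives an at least 140-fold higher number from compound 3 to compound 4 (2.15 log units; beyond the scatter), so at this position a single added methyl can decide whether the effect appears at all. Ethyl in place of hydrogen on the oxygen gives an at least 30-fold higher number from compound 2 to compound 4 (1.48 log units; beyond the scatter), so the gain that methyl brought over hydrogen does not extend to ethyl. The value of compound 4 is a limit and not a number: the limit of > 100 ug/mL in this assay, at which 1 of the 4 values shown sits.

The compounds shown leave open how a longer chain such as propoxy, or an amine at this position, would behave. They also leave open whether any group other than methoxy matches its effect.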